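The compounds below may be only part of what the source reports. "The series", "measured", "known", "first", "only" and "open" are said of these compounds alone.

Compound 2 `COc1cc(-c2nn(-c3cccc(NC(=O)c4cccc(C(F)(F)F)c4)c3)cc2-c2ccncc2)ccc1Cl` is one of three compounds tested in a functional assay on Malme-3M cells (Homo sapiens) for inhibition, read by sulforhodamine B assay, with a stated time of 48 h; on this read-out higher numbers stand for weaker inhibition of growth and lower numbers for stronger inhibition of growth. For compound 2 this assay reports only a limit, > 50000 nM, and no number (the limit of > 50000 nM in this assay, at which 1 of the 3 values shown sits). Compound 1 `O=C(Nc1cccc(-n2cc(-c3ccncc3)c(-c3ccc(Cl)c(O)c3)n2)c1)Nc1cccc(C(F)(F)F)c1` gives 20100 nM in this assay. Compound 3 `O=C(Nc1cccc(-n2cc(-c3ccncc3)c(-c3ccc(Cl)c(O)c3)n2)c1)Nc1ccc(Cl)c(Cl)c1` gives 8100 nM. Among the compounds with values here, the only step measured between two compounds that differ in one place, a 2.5-fold lower number from compound 1 to compound 3 (0.39 log units; beyond the scatter), swaps a group on an amide-type nitrogen. Compound 4 `COc1cc(-c2nn(-c3cccc(NC(=O)Nc4cccc(C(F)(F)F)c4)c3)cc2-c2ccncc2)ccc1Cl` differs from compound 2 by a different change: (3-(trifluoromethyl)phenyl)amino in place of 3-(trifluoromethyl)phenyl on a carbonyl carbon. Within the data shown here, no measured step covers this change, so the expectation for compound 4 can lean only on compound 1, which carries the entering group and gives 20100 nM. Compound 4 is therefore expected to show an at least 1.4-fold lower number from compound 2 to compound 4 (0.15 log units; that floor lies within the scatter). Compound 4 is estimated at 35000 nM, between 12000 nM and 100000 nM.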

Compound 4, concentration for total growth inhibition: 2410 nM
Compound 4: the middle estimate sits 15-fold (1.16 log units) above what was measured; measured number outside the range, below it.
By their numbers in this assay, from the lowest: compound 4; then compound 3; then compound 1. At a limit, above all of these: compound 2.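

In this assay, within the data shown here, (3-(trifluoromethyl)phenyl)amino in place of 3-(trifluoromethyl)phenyl on a carbonyl carbon, which adds one hydrogen-bond donor, gives an at least 20-fold lower number from compound 2 to compound 4 (1.31 log units; beyond the scatter), the only measured step at this place. Compound 2 has a limit and no number, so the size of this step is only a floor: the limit of > 50000 nM in this assay, at which 1 of the 4 values shown sits. Methyl in place of hydrogen on an oxygen on an aromatic ring, a second place, goes the same way, with an 8.3-fold lower number from compound 1 to compound 4 (0.92 log units; beyond the scatter). As far as these compounds go, whether a longer chain in place of the entering amino nitrogen, or an ethyl group on that oxygen, would go the same way stays open.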